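This account rests on a few compounds, and the source may have more. Where it says the series, first, only, none or still open, it means among the compounds named here.

In an ADME assay on CEM-SS cells (Homo sapiens) for cytotoxicity, read by XTT assay, with a stated time of 7 days (a lower number here means that less compound is tolerated, a higher number that more compound is tolerated), compound 1 `COC(=O)c1c(C)cc(O)c(=O)c(O)c1Br` gives 7600 nM, compound 2 `COC(=O)c1cc(O)c(=O)c(O)cc1C` gives 15000 nM, and compound 3 `CCOC(=O)c1cc(O)c(=O)c(O)cc1C` gives 22000 nM. Compound 3 therefore lies within the scatter of compound 2, while its number is clearly higher than that of compound 1. Compound 4 `CC(=O)c1cc(O)c(=O)c(O)cc1C` differs from compound 3 as follows: methyl in place of ethoxy on a carbonyl carbon. In words, this is methyl in place of ethoxy on a carbonyl carbon, or ethoxycarbonyl to acetyl. The nearest evidence, a change within that ethoxy group, is a 1.5-fold higher number from compound 2 to compound 3 (0.17 log units; within the scatter). The other measured change, hydrogen in place of bromo, is a 2.0-fold higher number from compound 1 to compound 2 (0.30 log units; within the scatter). Among the compounds with values here, both stay within the scatter, and no measured compound carries acetyl, so no step beyond the scatter is expected in this assay. The expected change is a 1.5-fold lower number from compound 3 to compound 4 (0.17 log units; within the scatter). Compound 4 is estimated at 15000 nM, with an expected range of 6000 nM to 40000 nM.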

Compound 4, half-maximal cytotoxic concentration: 20000 nM
Estimate against measurement, compound 4: 1.3-fold (0.12 log units) below, and the stated range covers the measured number.
By their numbers in this assay, from the lowest: compounds 1, 2, 4 and 3 (each within the scatter of the next, the first and the last beyond it).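

In this assay, the step that drops the ester oxygen and replaces ethoxy with methyl gives a 1.1-fold lower number from compound 3 to compound 4 (0.04 log units; within the scatter), and the matching step from methoxy gives a 1.3-fold higher number from compound 2 to compound 4 (0.12 log units; within the scatter). The earlier compounds shown here changed only the chain on the ester oxygen, whereas these steps change the group on the carbonyl carbon itself, and both stay within the scatter. Nothing shown explains why this swap leaves the number so little changed. From the compounds shown here alone, whether an amine, a hydroxyl giving a carboxylic acid, or a longer chain on that carbonyl carbon would also stay within the scatter remains open.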